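The source may hold more compounds than are shown below. What is called first, only, known or untested is meant among the compounds shown, and "the series" means these compounds.

Working notes on a set of carbamates sharing one core. Compound 1 `CC(C)(C)OC(=O)N1CCC(CCOC(=O)N2CCc3c2ccc(S(C)(=O)=O)c3Cl)CC1` gives 530 nM in a functional assay on CHO cells for agonist activity at Glucose-dependent insulinotropic receptor (Homo sapiens), read by a luciferase reporter and cAMP accumulation, with a stated time of 2 h (a lower number here means that less compound is needed, a higher number that more compound is needed for the effect), and compound 2 `Cc1c(S(C)(=O)=O)ccc2c1CCN2C(=O)OCCC1CCN(C(=O)OC(C)(C)C)CC1` gives 770 nM in this assay. The change methyl in place of chloro on an aromatic carbon produced a 1.5-fold higher number from compound 1 to compound 2 (0.16 log units; within the scatter). Compound 3 `CC(C)(C)OC(=O)N1CCC(CCOC(=O)N2CCc3cc(S(C)(=O)=O)cc(Cl)c32)CC1` holds the same atoms joined differently; the difference between the two cores is not broken down here. In this assay compound 3 gives 21 nM, the lowest of the three numbers.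

Compound 4 `Cc1cc(S(C)(=O)=O)cc2c1N(C(=O)OCCC1CCN(C(=O)OC(C)(C)C)CC1)CC2` awaits measurement. It differs from compound 3 by methyl in place of chloro on an aromatic carbon, the same kind of change as that from compound 1 to compound 2, but with the place now meta to a methylsulfonyl group rather than ortho to a methylsulfonyl group. Because the earlier step of a 1.5-fold higher number from compound 1 to compound 2 (0.16 log units; within the scatter) stayed within the scatter, a small step is expected, a 1.4-fold higher number from compound 3 to compound 4 (0.15 log units; within the scatter). Compound 4 is therefore estimated at 30 nM, most likely between 12 nM and 80 nM.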

Compound 4, half-maximal effective concentration in the Glucose-dependent insulinotropic receptor assay: 44 nM
For compound 4 the middle estimate is 1.5-fold (0.17 log units) below the measured one; the measured number falls inside the stated range.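

In the Glucose-dependent insulinotropic receptor assay compound 3 gives 21 nM and compound 4 gives 44 nM; methyl in place of chloro gives a 2.1-fold higher number from compound 3 to compound 4 (0.32 log units; beyond the scatter). Set beside the earlier step, the two cores do not separate: the same change on two cores in the Glucose-dependent insulinotropic receptor assay, a 1.5-fold higher number (0.16 log units; within the scatter) from compound 1 to compound 2 and a 2.1-fold higher number (0.32 log units; beyond the scatter) from compound 3 to compound 4, 1.4-fold (0.16 log units) apart, within the scatter of two such steps. The change thus carries across these two cores with a step of similar size, but two pairs show no general rule for other cores. In a physicochemical assay for lipophilicity, read by HPLC, measured as octanol-water partition, at pH 7.4 (a lower number here means a more polar compound, a higher number a more lipophilic compound), compound 3 gives 3.2 and compound 4 gives 3.2, which is no change at the digits printed from compound 3 to compound 4 (within the scatter).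

Still open, on these data alone, is how other groups at this place, such as fluoro, methoxy, nitrile or an amine, would read in the Glucose-dependent insulinotropic receptor assay on either core. Also open, as far as these compounds go, is whether the same step would hold with the tert-butyl carbamate replaced, for example by a pyrimidine or a carboxylic acid.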